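Removing a Methoxy Group on Two Related Cores

The source may report more compounds than this note shows. Statements on the series, on what has been measured and on what is new or still open speak of the compounds shown alone.

Of the compounds shown here, three have so far been measured in a functional assay on LM7 cells (Homo sapiens) for antiproliferative activity, read by MTT assay, with a stated time of 72 h; on this read-out lower numbers stand for stronger inhibition and higher numbers for weaker inhibition. Compound 1 `COc1ccc2oc(CSC(=S)N3CCOCC3)cc(=O)c2c1` gives 11000 nM. Compound 2 `COc1ccc2occ(CSC(=S)N3CCCCC3)c(=O)c2c1` gives 4700 nM in this assay, the lowest of the three numbers. Compound 3 `O=c1cc(CSC(=S)N2CCOCC2)oc2ccccc12` gives 25200 nM in this assay.

Compound 1 and compound 3 differ in one place only: hydrogen in place of methoxy on an aromatic carbon. That single change produced a 2.3-fold higher number from compound 1 to compound 3 (0.36 log units; beyond the scatter), a modest weakening. Compound 2 and compound 1 are built on different cores, and the difference between the two cores is not broken down here.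

Compound 4 `O=c1c(CSC(=S)N2CCCCC2)coc2ccccc12` has not yet been measured. It stands to compound 2 exactly as compound 3 stands to compound 1, the same change on the same kind of place: hydrogen in place of methoxy on an aromatic carbon. Because the same change on the other core gave a 2.3-fold higher number from compound 1 to compound 3 (0.36 log units; beyond the scatter), a step of similar size is expected here, estimated as a 2.3-fold higher number from compound 2 to compound 4 (0.36 log units; beyond the scatter). Compound 4 is therefore expected to give about 10800 nM in this assay, with a likely range from 5000 nM to 25000 nM, resting on a single measured precedent.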

Compound 4, half-maximal inhibitory concentration: 4600 nM
Beside the measured number, compound 4's estimate is 2.3-fold (0.37 log units) above it, outside the stated range (below it).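

On the core of compound 2, hydrogen in place of methoxy gives a 1.0-fold lower number from compound 2 to compound 4 (0.01 log units; within the scatter) in this assay, so this pair cannot be told apart on this read-out. A step beyond the scatter on one core and a step within it on the other might look like a clear contrast, yet the gap between them is too small to show that the outcome depends on the core: the same change on two cores in this assay, a 2.3-fold higher number (0.36 log units; beyond the scatter) from compound 1 to compound 3 and a 1.0-fold lower number (0.01 log units; within the scatter) from compound 2 to compound 4, 2.3-fold (0.37 log units) apart, within the scatter of two such steps. The two steps therefore neither prove that the change carries over from one core to the other nor prove that it fails to, and two pairs are too few to set a rule for the series.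

The compounds shown leave open how other groups on this aromatic carbon, such as ethoxy, a chlorine atom or an amine, would read in this assay. Within the data shown here, they also leave open whether the same change on a third core would give a step closer to the one from compound 1 to compound 3 or to the one from compound 2 to compound 4.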